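Aryl exchange on the shared core, compound 2 to compound 3

The compounds below may be only part of what the source reports. "The series", "measured", "known", "first", "only" and "open" are said of these compounds alone.

compound 1 `COc1cc(-c2ccnc3cc(-c4ccc(C)cc4)nn23)cc(OC)c1OC` gives 3 nM
compound 2 `COc1cc(-c2ccnc3cc(-c4ccc5cnn(C)c5c4)nn23)cc(OC)c1OC` gives 233 nM

In a functional assay on A549 cells (Homo sapiens) for inhibition, read by CCK-8 assay, with a stated time of 48 h (on this read-out higher numbers stand for weaker inhibition and lower numbers for stronger inhibition), compound 2 holds the higher of the two numbers, at 233 nM. Compound 3 `COc1ccc(-c2cc3nccc(-c4cc(OC)c(OC)c(OC)c4)n3n2)cc1F` differs from it by 3-fluoro-4-methoxyphenyl in place of 1-methyl-1H-indazol-6-yl on an aromatic carbon, with 3-fluoro-4-methoxyphenyl in place of 1-methyl-1H-indazol-6-yl on an aromatic carbon. Within the data shown here, one measured step bears on this: a 78-fold higher number from compound 1 to compound 2 (1.89 log units; beyond the scatter), when 1-methyl-1H-indazol-6-yl replaced 4-methylphenyl. Compound 3 returns to a substituted phenyl, so a large move back in this assay towards stronger inhibition is expected, though this rests on a single step. The expected size is a 16-fold lower number from compound 2 to compound 3 (1.19 log units; beyond the scatter). Compound 3 is estimated at 15 nM, within a range of 3 nM to 80 nM.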

Compound 3, half-maximal inhibitory concentration: 545 nM
Compound 3: the middle estimate sits 36-fold (1.56 log units) below what was measured; the whole stated range lies below it.
By their numbers in this assay, from the lowest: compound 1; then compound 2; then compound 3.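

In this assay a substituted phenyl does not by itself restore the low number: the series shows a 180-fold higher number from compound 1 to compound 3 (2.26 log units; beyond the scatter) and also a 2.3-fold higher number from compound 2 to compound 3 (0.37 log units; beyond the scatter) on this aromatic carbon. Among the three groups tested here, 4-methylphenyl alone gives a low number, so the presence of a single phenyl ring does not settle the read-out, and compound 3 goes against any such reading. No evidence is available that explains these steps. Open, from the compounds shown here alone, is whether the fluorine or the methoxy of compound 3 accounts for the higher number. Also open, going by these compounds, is how 4-ethylphenyl or 4-aminophenyl would compare with 4-methylphenyl.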